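Phenyl to 2,6-dichlorophenyl: a step from compound 1

This account rests on a few compounds, and the source may have more. Where it says the series, first, only, none or still open, it means among the compounds named here.

Within the data shown here, the three measured members were tested in an assay on HEK293 cells for inhibition of cyclin-dependent kinase 14 (Homo sapiens), with a stated time of 4 h; on this read-out lower numbers stand for stronger inhibition and higher numbers for weaker inhibition. Compound 1 `CN(C)C/C=C/C(=O)Nc1cccc(S(=O)(=O)N2CCC(NC(=O)c3n[nH]cc3NC(=O)c3ccccc3)CC2)c1` gives 1000 nM in this assay. Compound 3 `CN(C)CC/C=C/C(=O)Nc1cccc(N2CCC(NC(=O)c3n[nH]cc3NC(=O)c3c(Cl)cccc3Cl)CC2)c1` gives 1000 nM, level with compound 1 at the digits shown, and compound 2 `CN(C)C/C=C/C(=O)Nc1cccc(CN2CCC(NC(=O)c3n[nH]cc3NC(=O)c3c(Cl)cccc3Cl)CC2)c1` gives 500 nM, which also lies within the scatter of compound 1. Among the measured compounds shown here, all three values thus sit within the scatter of one another, and no two measured compounds differ in only one place, so no single step can be read from the measured set.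

Compound 4 `CN(C)C/C=C/C(=O)Nc1cccc(S(=O)(=O)N2CCC(NC(=O)c3n[nH]cc3NC(=O)c3c(Cl)cccc3Cl)CC2)c1` is the next member and has not yet been measured. Against compound 1 the difference is 2,6-dichlorophenyl in place of phenyl on a carbonyl carbon, the rest of the structure unchanged. Compounds 2 and 3 already carry the 2,6-dichlorophenyl and give values within the scatter of compound 1, but other parts of their structures differ as well, so they do not settle the direction of this change on its own. The expected step in this assay, a 1.7-fold lower number from compound 1 to compound 4 (0.22 log units; within the scatter), is a modest one toward a lower number, possibly no larger than the scatter. The estimated value for compound 4 in this assay is 600 nM, with a range of 200 nM to 1500 nM.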

Compound 4, half-maximal inhibitory concentration: 50 nM
Compound 4: the middle estimate sits 12-fold (1.08 log units) above what was measured; the measured number lies below the stated range.
By their numbers in this assay, from the lowest: compound 4; then compounds 2, 1 and 3 (each within the scatter of the next).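

In this assay, the place on the carbonyl carbon whose other neighbour is an amide-type nitrogen proves decisive on the core of compound 1: 2,6-dichlorophenyl in place of phenyl gives a 20-fold lower number from compound 1 to compound 4 (1.30 log units; beyond the scatter), a large step beyond the scatter. Compounds 2 and 3 carry the same 2,6-dichlorophenyl but, with other parts of their structures also different, only hinted at this; compound 2 gives (500 nM) and compound 3 gives (1000 nM), so the presence of this group does not by itself bring a number as low as that of compound 4 (50 nM). Nothing measured here accounts for the size of the step.

The compounds shown leave open whether both chlorines are needed, as they include no 2-chlorophenyl, 2,6-difluorophenyl or 2,6-dimethylphenyl member for comparison with phenyl and 2,6-dichlorophenyl. As far as these compounds go, the size of this step on the structures of compounds 2 and 3 also remains unknown: neither has a phenyl partner in the set, so the change has been read on the core of compound 1 alone.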